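Replacing the tetrazole methyl with a methoxycarbonyl group

The compounds below may be only part of what the source reports. "The series", "measured", "known", "first", "only" and "open" are said of these compounds alone.

Compound 1 `CCCCCCCCc1ccc(OCC(=O)Cn2nnc(C)n2)cc1`: < 5%
Compound 2 `CCCCCCCCc1ccc(OCC(=O)Cn2nnc(-c3cccc(C(=O)OC)c3)n2)cc1`: 19%
Compound 3 `CCCCCCCCc1ccc(OCC(=O)Cn2nnc(-c3ccccn3)n2)cc1`: 30%

All three measured compounds share one core and were tested in an ADME assay on S9 fraction from liver (Rattus norvegicus) for metabolic stability, read by LC-MS, using NADPH, with a stated time of 30 min; a higher number here means that more of the compound is left, a lower number that less of the compound is left. In this assay, among the compounds with values here, compound 1 gives < 5%, which is a limit of the assay and not a number; it is the one value of the three that sits at that limit (the limit of < 5% in this assay, at which 1 of the 3 values shown sits). Compound 2 gives 19% in this assay, and compound 3 gives 30%. Compound 4 `CCCCCCCCc1ccc(OCC(=O)Cn2nnnc2C(=O)OC)cc1` has not yet been measured. It differs from compound 1 in one place: 5-(methoxycarbonyl)-1H-tetrazol-1-yl in place of 5-methyl-2H-tetrazol-2-yl on a saturated chain carbon bound to a carbonyl carbon. Within the data shown here, the steps that bear on it are a number at least 14 percentage points higher from compound 1 to compound 2 (beyond the scatter) and a number at least 25 percentage points higher from compound 1 to compound 3 (beyond the scatter), while a number 11 percentage points higher from compound 2 to compound 3 (beyond the scatter) compares the two larger groups with each other. In compound 4 the methoxycarbonyl group enters on the tetrazole itself rather than on a phenyl, and the ring is joined through a different nitrogen, so these steps are only a loose guide. A step of a number at least 5 percentage points higher from compound 1 to compound 4 (that floor lies within the scatter) is expected, in the same direction. Compound 4 is estimated at 10%, within a range from 2% to 25%.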

Compound 4, percent of the compound remaining: 38%
Compound 4: middle estimate off by 28 percentage points, on the low side, and the stated range ends below it.
By their numbers in this assay, from the lowest: compound 2; then compounds 3 and 4 (each within the scatter of the next). At a limit, below all of these: compound 1.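

In this assay, within the data shown here, the change to 5-(methoxycarbonyl)-1H-tetrazol-1-yl gives a number at least 33 percentage points higher from compound 1 to compound 4 (beyond the scatter) and counts as large, whereas the earlier steps from compound 1 were printed as at least modest. At this place, on a saturated chain carbon bound to a carbonyl carbon, a second aromatic ring on the tetrazole is therefore not required for more of the compound to be left, as compound 4 carries none. The true size of the step stays unknown, as it is measured from a limit and only its floor can be read: the limit of < 5% in this assay, at which 1 of the 4 values shown sits.

The compounds shown leave open whether the step belongs to the methoxycarbonyl group or to the change in how the tetrazole is joined, as the two change together here. They also leave open how a carboxylic acid or a primary amide in place of the methoxycarbonyl group would behave in this assay on the same tetrazole.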